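A few compounds are considered here, and "the series" means these few. Any claim that something is new, unique, unknown or untested is made for them only; others in the source may bear on it.

Measured compounds, with values in a functional assay on NALM-6 cells (Homo sapiens) for cytotoxicity, with a stated time of 72 h; a lower number here means that less compound is needed, a higher number that more compound is needed for the effect:

- Compound 1 `C=C[C@@](C)(/C=C/c1ccc(O)c(/C=C/C(=O)O)c1)CCC=C(C)C`: > 43400 nM, a limit
- Compound 2 `C=C[C@@](C)(/C=C/c1ccc(O)c(/C=C/c2ccc(F)cc2)c1)CCC=C(C)C`: > 43400 nM, a limit

Neither compound has a numerical value in this assay. Compound 2 stands only at > 43400 nM, which is a limit. The same holds for compound 1, and both results sit together at one ceiling: the limit of > 43400 nM in this assay, at which 2 of the 2 values shown sit.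

Compound 3 `C=C[C@@](C)(/C=C/c1ccc(O)c(/C=C/c2ccc(Cl)cc2)c1)CCC=C(C)C` has not yet been measured. It differs from compound 2 by a single exchange, (chloro in place of fluoro on an aromatic carbon), with chloro in place of fluoro on an aromatic carbon, para to a large group.

Among the compounds with values here, the only measured step that bears on this change is a step that the two limits leave unreadable from compound 1 to compound 2. That step swapped a different group, and it has no readable size, so it offers no measure for the exchange here. No step beyond the usual scatter is therefore expected in this assay, and no direction can be assigned. Compound 3 may well be reported only as a limit too.

The expected step is an at least 1.0-fold lower number from compound 2 to compound 3 (0.03 log units; that floor lies within the scatter). For compound 3 the estimated value is 40000 nM, with an expected range from 15000 nM to 70000 nM.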

Compound 3, half-maximal effective concentration: > 43400 nM
Compound 3 gave a limit, no number; the forecaster's own chance of this, stated with the estimate: 70%; middle value at least 1.0-fold (0.03 log units) from the limit.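

In this assay compound 3 gives > 43400 nM, a limit and not a number. Within the data shown here, no step among compound 1, compound 2 and compound 3 can be read, as all three results sit at one ceiling: the limit of > 43400 nM in this assay, at which 3 of the 3 values shown sit. The compounds shown leave open what number each would have, and whether either exchange alters it at all.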